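This account rests on a few compounds, and the source may have more. Where it says the series, first, only, none or still open, it means among the compounds named here.

Four compounds sharing one core are at issue here, and three of them have been tested in a functional assay on CWR22R cells (Homo sapiens) for antiproliferative activity, with a stated time of 96 h; a higher number here means a weaker inhibitor, a lower number a stronger inhibitor. Compound 1 `Cc1cc(=O)oc2cc(OCC(=O)c3ccc(C(C)(C)C)cc3)ccc12` gives 22300 nM. Compound 3 `CC(C)(C)c1ccc(C(=O)COc2ccc3c(C(F)(F)F)cc(=O)oc3c2)cc1` is reported as "not active" (no number reported).

Compound 2 `Cc1cc(=O)oc2cc(OCC(=O)c3cccc(C(F)(F)F)c3)ccc12` gives > 100000 nM, which is a limit of the assay and not a number. It therefore stands at the limit of > 100000 nM in this assay, at which 1 of the 3 values shown sits.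

Compound 4 `O=C(COc1ccc2c(C(F)(F)F)cc(=O)oc2c1)c1cccc(C(F)(F)F)c1` has not yet been measured. It departs from compound 2 by trifluoromethyl in place of methyl on an aromatic carbon, opposite the ring oxygen.

Within the data shown here, the two compounds already tested offer the only guide, since they differ from each other by the same replacement. Compound 1 with methyl gives 22300 nM, whereas compound 3 with trifluoromethyl is reported as "not active" (no number reported). No gain in potency is therefore expected, and the estimated step of a number no higher from compound 2 to compound 4 (the limit leaves the size open) is expected to stay within the scatter. For compound 4 the expected value is 100000 nM, with an estimated range of 40000 nM to 300000 nM, and a report of only a limit is the likeliest outcome.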

Compound 4, half-maximal inhibitory concentration: "not active" (no number reported)
Nothing numeric was reported for compound 4; the estimate stays without a comparison.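

Between compound 2 and compound 4 no step can be read in this assay: compound 2 has only a limit of the assay, and compound 4 has no number at all. The compounds shown leave open how far trifluoromethyl in place of methyl changes antiproliferative activity.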